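Chlorophenyl placement in a hydroxyphenyl-pyridine series

This account rests on a few compounds, and the source may have more. Where it says the series, first, only, none or still open, it means among the compounds named here.

Working notes on the series tested in a functional assay on T47D cells (Homo sapiens) for cytotoxicity, read by CCK-8 assay and cell counting, with a stated time of 2 days; a lower number here means a stronger inhibitor, a higher number a weaker inhibitor. Three analogues share one core. Compound 1 `Oc1cccc(-c2cc(-c3cccnc3)nc(-c3cccc(Cl)c3)c2)c1` carries a pyridin-3-yl group and a 3-chlorophenyl group; in this assay compound 1 is entered as "not determined" (no result reported), so no result is reported for it. Compound 2 `Oc1cccc(-c2cc(-c3ccncc3)nc(-c3cccc(Cl)c3)c2)c1` carries a pyridin-4-yl group and the same 3-chlorophenyl group; in this assay compound 2 is likewise entered as "not determined" (no result reported), so its standing in this assay cannot be placed on the numbers shown, and the one further analogue without a number gives no anchor either. For the measured compounds named here, compound 3 `Oc1cccc(-c2cc(-c3cccc(Cl)c3)nc(-c3ccco3)c2)c1` replaces the pyridyl group with a furan-2-yl group, and in this assay compound 3 gives 3570 nM, the only number in the set.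

The step of interest leads from compound 2 to compound 4 `Oc1cccc(-c2cc(-c3ccncc3)nc(-c3ccc(Cl)cc3)c2)c1`: 4-chlorophenyl in place of 3-chlorophenyl on an aromatic carbon. Going by the values given here, no pair of measured compounds differing in one place is available, so the size of this step cannot be read from the series. With only the value of compound 3 as a reference for the core, a step of modest size is expected, in either direction, and nothing beyond the usual scatter is assumed. For compound 4 in this assay the expected value is 3000 nM, with a range from 800 nM to 12000 nM.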

Compound 4, half-maximal inhibitory concentration: 3330 nM
Beside the measured number, compound 4's estimate is 1.1-fold (0.05 log units) below it; measured number inside the range.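

In this assay, for the compounds shown here, compound 4 gives 3330 nM but compound 2 has no single number, so no step between compound 2 and compound 4 can be read. The compounds shown leave open whether 4-chlorophenyl in place of 3-chlorophenyl shifts the read-out at all. No supporting evidence bears on this result.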